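The source may hold more compounds than are shown below. What is called first, only, known or untested is meant among the compounds shown, and "the series" means these compounds.

Measured so far:
- compound 1, `C=CC(=O)Nc1cc(Nc2ncc(Cl)c(N3CCc4sccc4C3)n2)c(OC)cc1N1CCN(C)CC1`: in a functional assay on A-431 cells (Homo sapiens) for cytotoxicity, read by MTT assay (a higher number here means a weaker inhibitor, a lower number a stronger inhibitor), compound 1 gives > 50000 nM, which is a limit of the assay.
- compound 2, `C/C=C/C(=O)Nc1cc(Nc2ncc(Cl)c(N3CCc4sccc4C3)n2)c(OC)cc1N(C)CCN(C)C`: compound 2 gives 152 nM.
- compound 3, `C=CC(=O)Nc1cc(Nc2ncc(Cl)c(N3CCc4sccc4C3)n2)c(OC)cc1N(C)CCN(C)C`: compound 3 gives 5490 nM.

Among the compounds with values here, compound 2 has the lowest number of the two numbers known; the nearest is compound 3, with a 36-fold higher number from compound 2 to compound 3 (1.56 log units; beyond the scatter), the third value being a limit (the limit of > 50000 nM in this assay, at which 1 of the 3 values shown sits).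

Compound 4, `COc1cc(N(C)CCN(C)C)c(NC(=O)/C=C/C(C)C)cc1Nc1ncc(Cl)c(N2CCc3sccc3C2)n1`, is not yet measured. It differs from compound 2 in one place: isopropyl in place of methyl on a double-bonded chain carbon bound to a double-bonded chain carbon.

Within the data shown here, the only measured step at the same part of the molecule is the exchange of the chain on the carbonyl, a 36-fold higher number from compound 2 to compound 3 (1.56 log units; beyond the scatter), which shows that what stands on that double-bonded chain carbon can move the number strongly. The other step, an at least 9.1-fold lower number from compound 1 to compound 3 (0.95 log units; beyond the scatter), concerns a different position and does not bear on this change. Among the measured compounds shown here, no measured pair shows a methyl exchanged for an isopropyl at this place, so the direction is open. The expectation is a step no larger than modest, a 2.0-fold higher number from compound 2 to compound 4 (0.30 log units; within the scatter), leaning to a somewhat higher number, with the number for compound 4 estimated at 300 nM and likely between 60 nM and 2500 nM.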

Compound 4, half-maximal inhibitory concentration: 21300 nM
Compound 4: the middle estimate sits 71-fold (1.85 log units) below what was measured; the whole stated range lies below it.
By their numbers in this assay, from the lowest: compound 2; then compound 3; then compound 4. At a limit, above all of these: compound 1.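

In this assay, within the data shown here, the methyl on this double-bonded chain carbon cannot be exchanged for isopropyl without a heavy loss: the change gives a 140-fold higher number from compound 2 to compound 4 (2.15 log units; beyond the scatter), the largest single-place step so far. The earlier compounds shown here showed only that removing the methyl raised the number; this result shows that adding carbon at the same place raises it as well, so the methyl of compound 2 gives the lowest number of the three chains on the carbonyl carbon. The vinyl of compound 3 lies in the middle, with a 3.9-fold higher number from compound 3 to compound 4 (0.59 log units; beyond the scatter), so the number does not follow the size of the chain in one direction across compounds 2, 3 and 4.

Still open, on these data alone, is how an ethyl, a straight propyl chain or a dimethylamino group carried on this chain carbon would read, and therefore whether the loss in compound 4 belongs to branching or to chain length alone. Nothing measured here accounts for the size of the step from methyl to isopropyl.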